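Thiazolidinedione benzylidene series: benzyl swap on a second core

The compounds below may be only part of what the source reports. "The series", "measured", "known", "first", "only" and "open" are said of these compounds alone.

Measured so far:
- compound 1, `Nc1cccc(/C=C2\SC(=O)N(Cc3ccc(F)cc3)C2=O)c1`: 140000 nM
- compound 2, `Nc1cccc(/C=C2\SC(=O)N(Cc3cccc(Cl)c3)C2=O)c1`: 164000 nM
- compound 3, `C=C(Br)C(=O)Nc1ccc(/C=C2\SC(=O)N(Cc3ccc(F)cc3)C2=O)cc1`: 4600 nM

The three compounds were tested in a functional assay on FM3A cells (Mus musculus) for cytotoxicity, read by cell counting, with a stated time of 2 days; a higher number here means a weaker inhibitor, a lower number a stronger inhibitor. Compound 1 and compound 2 share the core of compound 1 and differ only by 3-chlorophenyl in place of 4-fluorophenyl on a saturated chain carbon bound to an amide-type nitrogen in a ring; the step of a 1.2-fold higher number from compound 1 to compound 2 (0.07 log units; within the scatter) is within the scatter, so the two values cannot be ordered. Compound 3 carries a different core; the difference between the two cores is not broken down here. Compound 3 gives the lowest number of the three, with its nearest neighbour being compound 1 and its furthest compound 2, both well beyond the scatter.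

Compound 4, `C=C(Br)C(=O)Nc1ccc(/C=C2\SC(=O)N(Cc3cccc(Cl)c3)C2=O)cc1`, has not yet been measured in this assay. It is related to compound 3 by 3-chlorophenyl in place of 4-fluorophenyl on a saturated chain carbon bound to an amide-type nitrogen in a ring, which is the same change as that from compound 1 to compound 2: the two "place" descriptions read the same word for word. That change has been made once among the measured compounds, and there it moved the number by a 1.2-fold higher number from compound 1 to compound 2 (0.07 log units; within the scatter), a step inside the scatter. The expectation for compound 4 therefore rests on a single prior example on a different core.

On that basis the step from compound 3 to compound 4 is estimated at a 1.2-fold higher number from compound 3 to compound 4 (0.08 log units; within the scatter), essentially flat because a 1.2-fold higher number from compound 1 to compound 2 (0.07 log units; within the scatter) was itself inside the scatter. Compound 4 is thus expected to give about 5500 nM in this assay, with a range of 2300 nM to 13000 nM allowing for the uncertainty of transferring one observation to a second core.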

Compound 4, half-maximal inhibitory concentration: 6100 nM
Beside the measured number, compound 4's estimate is 1.1-fold (0.04 log units) below it; the range from low to high includes it.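

In this assay, the move from 4-fluorobenzyl to 3-chlorobenzyl on the second core gives a 1.3-fold higher number from compound 3 to compound 4 (0.12 log units; within the scatter), so the two values cannot be ordered. Set beside the same change on the core of compound 1, the step shows no difference between the two cores: the same change on two cores in this assay, a 1.2-fold higher number (0.07 log units; within the scatter) from compound 1 to compound 2 and a 1.3-fold higher number (0.12 log units; within the scatter) from compound 3 to compound 4, 1.1-fold (0.05 log units) apart, within the scatter of two such steps This shows only that the change leaves the number flat within the scatter on both cores; it does not show that a change with a real effect would carry over in the same way, and two pairs give no general rule for the series.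

The compounds shown include no pair that differs in one place between the two cores, so the gap between compound 3 and the compounds on the core of compound 1 stays unassigned to any single part of the structure. Also open, on these data alone, is whether an amine or a carboxylic acid on the benzyl ring, or a longer chain in place of the benzyl, would move the number on either core, and whether such a step would then match from one core to the other.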